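Hydroxy in Place of Methyl Beside the Ketone

The source may hold more compounds than are shown below. What is called first, only, known or untested is meant among the compounds shown, and "the series" means these compounds.

Measured so far:
Compound 1, `Cc1c(OCCCCOc2ccc(C(=O)O)cc2Cl)ccc(C(=O)CC2CCCC2)c1O`, gives 27.4%.
Compound 2, `COC(=O)c1ccc(OCCCCOc2ccc(C(=O)CC3CCCC3)c(C)c2C)cc1`, gives 24.2%.

Both numbers come from an assay on HEK293 cells for positive allosteric modulation of metabotropic glutamate receptor 3 (Rattus norvegicus), read by thallium flux, with a stated time of 2.5 min; on this read-out lower numbers stand for smaller maximal responses and higher numbers for larger maximal responses. Compound 2 stands at the lower of the two values, and compound 1 lies only a little higher, a gap that falls within the usual scatter of this assay, so the two cannot be told apart. Compound 3, `COC(=O)c1ccc(OCCCCOc2ccc(C(=O)CC3CCCC3)c(O)c2C)cc1`, has not been measured yet. It differs from compound 2 in one place: hydroxy in place of methyl on an aromatic carbon. For the measured compounds named here, no measured pair shows this exact change, so its size has to be guessed. Because compound 1, which also carries a hydroxy ortho to the carbonyl, gives 27.4% in this assay, only a small shift is expected. The estimated step of a number 2.8 percentage points higher from compound 2 to compound 3 (within the scatter) is expected to stay within the scatter. Compound 3 is therefore estimated at 27%, with a range from 15% to 40%.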

Compound 3, largest response reached (reported as percent of maximum), in percent of the reference or control that the assay uses: 22%
For compound 3 the middle estimate is 5 percentage points above the measured one; measured number inside the range.
By their numbers in this assay, from the lowest: compounds 3, 2 and 1 (each within the scatter of the next).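

In this assay, hydroxy in place of methyl on the aromatic carbon ortho to the (cyclopentylmethyl)carbonyl group gives a number 2.2 percentage points lower from compound 2 to compound 3 (within the scatter) and so leaves the maximal response indistinguishable, even though the swap adds a hydrogen-bond donor and a hydrogen-bond acceptor. The other end of the molecule tells the same story: 4-(methoxycarbonyl)phenyl in place of 4-carboxy-2-chlorophenyl gives a number 5.4 percentage points lower from compound 1 to compound 3 (within the scatter), so neither change separates these compounds. Nothing measured here explains why these swaps leave the response unresolved.

Still open, on these data alone, is whether an amine or a methoxy group on that same aromatic carbon would give a response clearly apart from these values. As far as these compounds go, it is also open whether a longer chain in place of the (cyclopentylmethyl)carbonyl group would move the response beyond the scatter.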